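Swapping the pyridine ring for a methoxyphenyl group

The compounds below may be only part of what the source reports. "The series", "measured", "known", "first", "only" and "open" are said of these compounds alone.

Measured compounds:
- compound 1 `Cc1cc2nn(-c3ccccc3)c(N)c2c(=O)[nH]1`: -11%
- compound 2 `Nc1c2c(=O)[nH]c(-c3ccccc3)cc2nn1-c1ccccc1`: 38%
- compound 3 `Nc1c2c(=O)[nH]c(-c3ccccn3)cc2nn1-c1ccccc1`: 6%

All three share one core and differ only in the group attached to one aromatic carbon. In an assay on isolated protein for inhibition of ribosomal protein S6 kinase alpha-1 (Homo sapiens), read by mobility shift assay, tested at 30 uM (a higher number here means more inhibition at the concentration tested (going by the name of the read-out), a lower number less inhibition), compound 3 gives 6%, the second highest of the three numbers: it sits above compound 1 by a number 17 percentage points higher from compound 1 to compound 3 (beyond the scatter) but well below compound 2, which carries a phenyl group, by a number 32 percentage points lower from compound 2 to compound 3 (beyond the scatter).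

Compound 4 `COc1ccccc1-c1cc2nn(-c3ccccc3)c(N)c2c(=O)[nH]1` has not yet been measured. It differs from compound 3 by 2-methoxyphenyl in place of pyridin-2-yl on an aromatic carbon. The entering group is, like the phenyl of compound 2, a six-membered aromatic ring of carbon only, now carrying a methoxy group. Within the data shown here, the closest measured step is the one from compound 2 to compound 3, where pyridin-2-yl in place of phenyl lowered the number by a number 32 percentage points lower from compound 2 to compound 3 (beyond the scatter); the step from compound 1 to compound 2, a number 49 percentage points higher from compound 1 to compound 2 (beyond the scatter), also shows that a carbon-only ring at this position raises inhibition. Running that change in reverse, compound 4 is expected to gain on compound 3 by roughly a number 26 percentage points higher from compound 3 to compound 4 (beyond the scatter). Whether the methoxy group adds or subtracts from this cannot be read from the three compounds, so the range is wide. The estimate for compound 4 in this assay is 32%, with a range from 8% to 56%.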

Compound 4, a percentage reported as inhibition, at one concentration (the size of the read-out at that concentration, not a potency): 3%
The estimate for compound 4 lay 29 percentage points above the measured number; measured number below the stated range.
By their numbers in this assay, from the lowest: compound 1; then compounds 4 and 3 (each within the scatter of the next); then compound 2.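

In this assay, the step of a number 3 percentage points lower from compound 3 to compound 4 (within the scatter) means that 2-methoxyphenyl and pyridin-2-yl cannot be told apart at this position, even though one ring is carbon only and the other holds a nitrogen. The step of a number 35 percentage points lower from compound 2 to compound 4 (beyond the scatter) adds the new finding: a carbon-only ring does not by itself keep the number of compound 2, and adding a single methoxy group to that phenyl ring is enough to lose much of it. A modest gain over the small methyl group remains, seen in a number 14 percentage points higher from compound 1 to compound 4 (beyond the scatter), so compound 2 still stands alone at the top of this set.

No measurement shown here explains the drop caused by the methoxy group. As far as these compounds go, it also remains open whether other groups on the phenyl ring, such as a fluorine atom or an amine, would lower the number in the same way.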